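The source may hold more compounds than are shown below. What is called first, only, known or untested is meant among the compounds shown, and "the series" means these compounds.

Working notes on the series in an assay on isolated protein for inhibition of activin receptor type-2A (Homo sapiens), read by 33P incorporation, with a stated time of 20 min, in the presence of a further agent that is not named here; a lower number here means a stronger inhibitor, a higher number a weaker inhibitor.

Of the compounds shown here, three have numbers so far. Compound 1 `COc1cc(-c2cnn3cc(OC)c(-c4cc(C)no4)nc23)ccn1` gives 3000 nM in this assay. Compound 2 `Cc1ccc(-c2cnc(N)c(C(=O)NC3CCCCC3)n2)cc1` gives 180 nM, and compound 3 `Cn1cc(-c2nc3c(-c4ccnc(OC5CC5)c4)cnn3cc2OCCCC(C)(C)O)cn1` gives 2900 nM. Compound 1 has the highest number of the three: its gap to compound 3 lies within the scatter, so the two cannot be ordered, while compound 2 lies well beyond the scatter from compound 1.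

The next compound, compound 4 `COc1cc(-c2cnn3cc(OC)c(-c4cnn(C)c4)nc23)ccn1`, is not yet measured. It differs from compound 1 in one place: 1-methyl-1H-pyrazol-4-yl in place of 3-methyl-1,2-oxazol-5-yl on an aromatic carbon. Among the compounds with values here, no measured pair reproduces this exact change, so its size cannot be read off a known step. What can be said is that compound 3 also carries a 1-methyl-1H-pyrazol-4-yl group on its core and gives 2900 nM, a number within the scatter of compound 1.

On that basis the step from compound 1 to compound 4 is expected to be small, likely none beyond the scatter, with a 1.2-fold lower number from compound 1 to compound 4 (0.08 log units; within the scatter) as the working expectation. Compound 4 is therefore estimated at 2500 nM, in a range from 800 nM to 8000 nM.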

Compound 4, half-maximal inhibitory concentration: 530 nM
Compound 4: the middle estimate sits 4.7-fold (0.67 log units) above what was measured, and the stated range ends above it.
By their numbers in this assay, from the lowest: compound 2; then compound 4; then compounds 3 and 1 (each within the scatter of the next).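

In this assay, within the data shown here, 1-methyl-1H-pyrazol-4-yl in place of 3-methyl-1,2-oxazol-5-yl gives a 5.7-fold lower number from compound 1 to compound 4 (0.75 log units; beyond the scatter), the first step that can be read in one place and one that lies beyond the scatter. This aromatic carbon, next to the ring nitrogen and ortho to a methoxy group, therefore responds to which five-membered aromatic ring it carries, even though the two groups have the same heavy-atom, donor and acceptor counts and differ in that a nitrogen and an oxygen leave while two nitrogens enter. No measurement in hand accounts for the size of this step.

Open, on these data alone, is whether the step follows from the hetero atoms of the ring, the place of its methyl or its point of attachment; a 1H-pyrazol-4-yl without the methyl, or a phenyl ring on this carbon, would bear on that. Also open, as far as these compounds go, is whether the same step holds on the shared core when the methoxy group ortho to this position gives way to a longer ether chain.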